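A few compounds are considered here, and "the series" means these few. Any claim that something is new, unique, unknown or untested is made for them only; others in the source may bear on it.

In a functional assay on HCT-116 cells (Homo sapiens) for inhibition, read by MTT assay, with a stated time of 2 days (on this read-out higher numbers stand for lower toxicity in this test and lower numbers for higher toxicity in this test), compound 1 `Nc1ccccc1NC(=O)CCCNCC(=O)Nc1cccc(Cl)c1` gives > 100000 nM, which is a limit of the assay and not a number. Compound 2 `Nc1ccccc1NC(=O)CCCNCC(=O)Nc1cc(Cl)ccc1Cl` gives > 100000 nM, again a limit. Compound 3 `COc1ccc(NC(=O)CNc2ccc(C(=O)Nc3ccccc3N)cc2)cc1`, which also carries 4-methoxyphenyl on an amide-type nitrogen, gives > 100000 nM, likewise a limit. Compound 1 therefore has no exact place on the scale, and no order can be read among these three compounds.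

Compound 4 `COc1ccc(NC(=O)CNCCCC(=O)Nc2ccccc2N)cc1`, not yet measured, differs from compound 1 in one place: 4-methoxyphenyl in place of 3-chlorophenyl on an amide-type nitrogen. In words, 4-methoxyphenyl stands in place of 3-chlorophenyl on an amide-type nitrogen. Among the compounds with values here, the one measured step on this part of compound 1 is a step that the two limits leave unreadable from compound 1 to compound 2, with chloro in place of hydrogen on an aromatic carbon, so it gives no size to carry over. No shift beyond the scatter, in either direction, is expected because of the limit of > 100000 nM in this assay, at which 3 of the 3 values shown sit. The expected change is a number no higher from compound 1 to compound 4 (the limit leaves the size open). For compound 4 the estimate is 100000 nM, with an expected range from 40000 nM to 200000 nM.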

Compound 4, concentration lethal to 50% of the cells: > 100000 nM
Compound 4: no number, only a limit; the forecaster's own chance of this, stated with the estimate: 80%; the middle value sits exactly at the limit.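

The steps from compound 1 and from compound 2 to compound 4 cannot be read in this assay, because these compounds all sit at the same limit of the assay: the limit of > 100000 nM in this assay, at which 4 of the 4 values shown sit.

The compounds shown leave open what exact value any of them has, and whether changing the group on the amide-type nitrogen shifts it at all.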